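The source may report more compounds than this note shows. Statements on the series, on what has been measured and on what is new or still open speak of the compounds shown alone.

Of the compounds shown here, three share one core and have been tested in a functional assay on M21 cells (Homo sapiens) for antiproliferative activity, read by sulforhodamine B assay, with a stated time of 48 h; a higher number here means a weaker inhibitor, a lower number a stronger inhibitor. Compound 1 `CCC(=O)Nc1cccc(S(=O)(=O)Oc2ccccc2C(C)C)c1` gives 25000 nM. Compound 2 `CC(C)C(=O)Nc1ccc(S(=O)(=O)Oc2ccccc2C(C)C)cc1` gives 11000 nM, and compound 3 `CC(C)C(=O)Nc1ccc(S(=O)(=O)Oc2ccccc2I)cc1` gives 13000 nM. On these numbers compound 3 sits second highest of the three, but its gaps to compound 2 and to compound 1 both lie within the scatter, so the three cannot be told apart. Within the data shown here, the only single-point step among them, a 1.2-fold higher number from compound 2 to compound 3 (0.07 log units; within the scatter), swaps iodo for isopropyl on an aromatic carbon and changes nothing beyond the scatter.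

Compound 4 `O=C(Nc1ccc(S(=O)(=O)Oc2ccccc2I)cc1)NC1CC1` has not yet been measured. It differs from compound 3 in one place: cyclopropylamino in place of isopropyl on a carbonyl carbon. Among the measured compounds shown here, no measured pair tests a change at this carbonyl carbon; the step from compound 2 to compound 3 touches a different part of the molecule. With nothing pointing either way, the expectation for compound 4 is a step of no change at the digits printed from compound 3 to compound 4 (within the scatter), that is, no movement beyond the scatter. Compound 4 is therefore estimated at 13000 nM, with a range from 4000 nM to 40000 nM.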

Compound 4, half-maximal inhibitory concentration: 11000 nM
The estimate for compound 4 lay 1.2-fold (0.07 log units) above the measured number; the range from low to high includes it.
By their numbers in this assay, from the lowest: compounds 2, 4, 3 and 1 (each within the scatter of the next, the first and the last beyond it).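

In this assay, putting cyclopropylamino in place of isopropyl on the carbonyl carbon gives a 1.2-fold lower number from compound 3 to compound 4 (0.07 log units; within the scatter), the first step shown at this carbonyl carbon. The change turns (isopropylcarbonyl)amino into (cyclopropylcarbamoyl)amino, bringing in a nitrogen with a hydrogen-bond donor and a three-membered ring, yet the read-out does not move beyond the scatter. Nothing measured here offers an explanation for this result.

Still open, as far as these compounds go, is whether a quite different group on this carbonyl carbon, such as a morpholine, a carboxylic acid or a longer alkyl chain, would move the number beyond the scatter. From the compounds shown here alone, the nitrogen and the ring also enter together, so their separate contributions remain unknown; methylamino or a cyclopropyl group attached directly to the carbonyl carbon would pull them apart.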